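From vinylsulfonyl to a methoxycarbonyl side chain

The source may report more compounds than this note shows. Statements on the series, on what has been measured and on what is new or still open speak of the compounds shown alone.

In a functional assay on HT-29 cells (Homo sapiens) for antiproliferative activity, read by MTT assay, with a stated time of 72 h (on this read-out lower numbers stand for stronger inhibition and higher numbers for weaker inhibition), compound 1 `C=CC(=O)Nc1ccc(Cl)c(S(=O)(=O)N(C)C)c1` gives > 30000 nM, which is a limit of the assay and not a number. Within the data shown here, compound 2 `C=CS(=O)(=O)Nc1ccc(Cl)c(S(=O)(=O)N(C)C)c1` gives 10200 nM, the only actual number so far. Compound 3 `COC(=O)/C=C/CNc1ccc(Cl)c(S(=O)(=O)N(C)C)c1` differs from it as follows: 3-(methoxycarbonyl)prop-2-en-1-yl in place of vinylsulfonyl on a nitrogen on an aromatic ring. Among the measured compounds shown here, one measured step bears on this nitrogen substituent, an at least 2.9-fold lower number from compound 1 to compound 2 (0.46 log units; beyond the scatter), and it lies beyond the scatter. That step compares only vinylcarbonyl with vinylsulfonyl and starts from a limit, so it shows that a change at this place can register but gives little guide to the size or direction here. For the measured compounds named here, no measured compound carries the entering group. The expected change is small, a 1.4-fold higher number from compound 2 to compound 3 (0.14 log units; within the scatter), towards weaker inhibition and within the scatter. For compound 3 the estimated value in this assay is 14000 nM, with an expected range of 4000 nM to 30000 nM.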

Compound 3, half-maximal inhibitory concentration: > 30000 nM
Compound 3: no number, only a limit (the forecaster's own chance of this, stated with the estimate: 35%); at least 2.1-fold (0.33 log units) between middle value and limit.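

In this assay compound 3 gives > 30000 nM, which is a limit of the assay and not a number. Replacing vinylsulfonyl with 3-(methoxycarbonyl)prop-2-en-1-yl on this nitrogen gives an at least 2.9-fold higher number from compound 2 to compound 3 (0.46 log units; beyond the scatter), so this change weakens inhibition measurably, whereas the earlier step showed only that the nitrogen substituent can matter. Vinylsulfonyl is now the only substituent here with a measured number, and the comparison of compound 1 with compound 3 cannot be read, since both sit at the same ceiling: the limit of > 30000 nM in this assay, at which 2 of the 3 values shown sit.

Going by these compounds, how far compound 3 lies past its limit remains open, so the full size of the step is unknown. Also open, on these data alone, is whether an ethylsulfonyl group, or a carboxylic acid in place of the methyl ester, would retain or improve on the inhibition seen with compound 2.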